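A few compounds are considered here, and "the series" means these few. Any claim that something is new, unique, unknown or untested is made for them only; others in the source may bear on it.

Values in a functional assay on K562 cells (Homo sapiens) for antiproliferative activity, read by CellTiter-Glo, with a stated time of 72 h (on this read-out lower numbers stand for stronger inhibition and higher numbers for weaker inhibition), for the measured compounds, each a limit of the assay and not a number:
compound 1 (`CO[C@@H]1[C@H](N(C)c2ncc(-c3c[nH]c4ccc(F)cc34)s2)C[C@H]2O[C@]1(C)n1c3ccccc3c3c4c(c5c6ccccc6n2c5c31)C(=O)NC4`) gives > 10000 nM as its limit
compound 2 (`CO[C@@H]1[C@H](N(C)c2ncc(-c3c[nH]c4ccc(Br)cc34)s2)C[C@H]2O[C@]1(C)n1c3ccccc3c3c4c(c5c6ccccc6n2c5c31)C(=O)NC4`) gives > 10000 nM as its limit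
compound 3 (`COc1ccc2[nH]cc(-c3cnc(N(C)[C@@H]4C[C@H]5O[C@@](C)([C@@H]4OC)n4c6ccccc6c6c7c(c8c9ccccc9n5c8c64)C(=O)NC7)s3)c2c1`) gives > 10000 nM as its limit

Compound 1 therefore has no number to stand on, and it shares its place with the other two: the series shows the limit of > 10000 nM in this assay, at which 3 of the 3 values shown sit, and no readable value. Compound 4 (`CO[C@@H]1[C@H](N(C)c2ncc(-c3c[nH]c4ccc(F)cc34)s2)C[C@H]2O[C@]1(C)n1c3ccccc3c3c4c(c5c6cc(Cl)ccc6n2c5c31)C(=O)NC4`) keeps all of compound 1 and adds one group to the shared core. The change is chloro in place of hydrogen on an aromatic carbon and it puts chloro in place of hydrogen on an aromatic carbon. Among the measured compounds shown here, only three steps bear on it: a step that the two limits leave unreadable from compound 1 to compound 2 with bromo in place of fluoro, a step that the two limits leave unreadable from compound 1 to compound 3 with methoxy in place of fluoro, and a step that the two limits leave unreadable from compound 2 to compound 3 with methoxy in place of bromo. None of them has a readable size, and none touches the carbon that takes the chloro. They give no direction for the new group, so no step beyond the scatter is expected in this assay on the evidence at hand. The expected change is a number no higher from compound 1 to compound 4 (the limit leaves the size open) as estimated here. Compound 4 is estimated at 10000 nM (expected range 3000 nM to 30000 nM).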

Compound 4, half-maximal inhibitory concentration: > 10000 nM
Compound 4 was reported as a limit (the forecaster's own chance of this, stated with the estimate: 85%); the middle value lies on the limit itself.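

In this assay compound 4 gives > 10000 nM, a limit of the assay and not a number. Compound 1 also stands at a limit, so no step can be read between compound 1 and compound 4. The compounds shown leave open how their activities rank and what chloro in place of hydrogen does, since all share one place: the limit of > 10000 nM in this assay, at which 4 of the 4 values shown sit.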